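Cytotoxicity at the assay ceiling across the aryl series

This account rests on a few compounds, and the source may have more. Where it says the series, first, only, none or still open, it means among the compounds named here.

In an ADME assay on MT4 cells (Homo sapiens) for cytotoxicity, read by MTT assay, with a stated time of 5 days (on this read-out lower numbers stand for higher toxicity in this test and higher numbers for lower toxicity in this test), compound 1 `Cc1cc(C#N)cc(C)c1Oc1nc(Nc2ccc(C#N)cc2)ncc1-c1ccco1` gives > 306000 nM, a limit of the assay rather than a number. Compound 2 `Cc1cc(C#N)cc(C)c1Oc1nc(Nc2ccc(C#N)cc2)ncc1-c1cccc2ccccc12` gives > 267000 nM in this assay, also a limit. Compound 3 `Cc1cc(C#N)cc(C)c1Oc1nc(Nc2ccc(C#N)cc2)ncc1-c1cncnc1` gives > 298000 nM in this assay, again a limit. Compound 1 therefore stands only at a limit, and the two further values are limits too. The steps a step that the two limits leave unreadable from compound 1 to compound 2 and a step that the two limits leave unreadable from compound 1 to compound 3 stay unreadable in size, as the limit of > 267000 nM in this assay, at which 1 of the 3 values shown sits, the limit of > 298000 nM in this assay, at which 1 of the 3 values shown sits, and the limit of > 306000 nM in this assay, at which 1 of the 3 values shown sits, show. Compound 4 `Cc1cc(C#N)cc(C)c1Oc1nc(Nc2ccc(C#N)cc2)ncc1-c1ccc2ccccc2c1` differs from compound 1 by naphthalen-2-yl in place of furan-2-yl on an aromatic carbon. The nearest measured step is a step that the two limits leave unreadable from compound 1 to compound 2, which gives no readable size, so in this assay no step beyond the scatter is expected. Compound 4 is estimated at 300000 nM, within 100000 nM to 600000 nM, most probably reported as a limit. The step this estimate means, an at least 1.0-fold lower number from compound 1 to compound 4 (0.00 log units; that floor lies within the scatter), is expected to be nil.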

Compound 4, half-maximal cytotoxic concentration: 8460 nM
For compound 4 the middle estimate is 35-fold (1.55 log units) above the measured one; measured number below the stated range.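

In this assay, among these compounds, naphthalen-2-yl on this aromatic carbon gives the first measured number rather than a limit, with an at least 36-fold lower number from compound 1 to compound 4 (1.55 log units; beyond the scatter) and an at least 35-fold lower number from compound 3 to compound 4 (1.54 log units; beyond the scatter). The naphthalene group alone does not go with this drop, since naphthalen-1-yl at the same carbon differs from it by an at least 31-fold lower number from compound 2 to compound 4 (1.49 log units; beyond the scatter). The steps among compound 1, compound 2 and compound 3 cannot be read.

Open, as far as these compounds go, is whether an amine or a carboxylic acid on the naphthalen-2-yl group would keep this lower number. Nothing shown gives a cause for the drop.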